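The source may report more compounds than this note shows. Statements on the series, on what has been measured and on what is new or still open speak of the compounds shown alone.

Measured in a functional assay on HCT-116 cells (Homo sapiens) for inhibition; on this read-out lower numbers stand for stronger inhibition and higher numbers for weaker inhibition:
- Compound 1 `CC(C)=CC(=O)OCc1cc(=O)oc2ccc(Cl)cc12`: > 10 ug/mL (a limit)
- Compound 2 `C/C=C/C(=O)OCc1cc(=O)oc2cc(OC)c(OC)cc12`: > 10 ug/mL (a limit)
- Compound 3 `COc1cc2oc(=O)cc(COC(=O)/C=C/c3cc(OC)c(OC)c(OC)c3)c2cc1OC`: 8.31 ug/mL

The series offers little firm ground, with most of it resting on (the limit of > 10 ug/mL in this assay, at which 2 of the 3 values shown sit). As far as these compounds go, compound 2 stands only at a limit, > 10 ug/mL, so its true position on this assay is unknown.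

The next compound, compound 4 `COc1cc2oc(=O)cc(COC(=O)/C=C/c3ccc(O)cc3)c2cc1OC`, differs from compound 2 in one place. It has 4-hydroxyphenyl in place of methyl on a double-bonded chain carbon bound to a double-bonded chain carbon.

For the measured compounds named here, no measured pair shows what a step of this kind does. Going by the values given here, the expectation therefore leans on compound 3, the only compound with a number, at 8.31 ug/mL. A modest move towards stronger inhibition in this assay is expected, though it may not clear the usual scatter. The expected step is an at least 1.2-fold lower number from compound 2 to compound 4 (0.09 log units; that floor lies within the scatter). The estimate for compound 4 is 8 ug/mL, with an expected range from 3.5 ug/mL to 18 ug/mL.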

Compound 4, half-maximal inhibitory concentration: 5.21 ug/mL
Compound 4: middle estimate off by 1.5-fold (0.19 log units), on the high side; low and high end bracket the measured number.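

At the place on a double-bonded chain carbon bound to a double-bonded chain carbon, exchanging methyl for 4-hydroxyphenyl yields a measured number in this assay, and the step reads an at least 1.9-fold lower number from compound 2 to compound 4 (0.28 log units; that floor lies within the scatter). For the compounds shown here, this is the first sign of how this change acts, but the floor alone does not carry it beyond the usual scatter. As far as these compounds go, compound 2 gives only a limit, so the true size of the step stays unknown because the comparison rests on that limit: the limit of > 10 ug/mL in this assay, at which 2 of the 4 values shown sit.

The compounds shown leave open whether a plain phenyl or a 4-aminophenyl at this place would read like 4-hydroxyphenyl, and so whether the ring or its hydroxyl accounts for the step. They also leave open how a longer chain between the ester carbonyl and the ring would read.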